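Fused aromatic group replacing cyclohexylmethylamino on the carbonyl

The source may hold more compounds than are shown below. What is called first, only, known or untested is meant among the compounds shown, and "the series" means these compounds.

Compound 1 `COc1cc(NC(C)CCCNC(=O)NCC2CCCCC2)c2ncccc2c1` is the reference. In an ADME assay on WI-38 cells (Homo sapiens), read by MTT assay, with a stated time of 72 h (a higher number here means a weaker inhibitor, a lower number a stronger inhibitor), compound 1 reaches only a limit, > 100000 nM. Compound 3 `COc1cc(NC(C)CCCNC(=O)NC2CCCCC2)c2ncccc2c1` likewise gives only a limit in this assay, > 100000 nM. Compound 2 `COc1cc(NC(C)CCCNC(=O)NCc2ccccc2)c2ncccc2c1` gives 35000 nM in this assay. The step of an at least 2.8-fold lower number from compound 1 to compound 2 (0.45 log units; beyond the scatter) exchanged a saturated ring for an aromatic one and lowered the number; an at least 2.8-fold higher number from compound 2 to compound 3 (0.45 log units; beyond the scatter) runs the other way, and a step that the two limits leave unreadable from compound 1 to compound 3 cannot be read, as the limit of > 100000 nM in this assay, at which 2 of the 3 values shown sit, holds both ends. Compound 4 `COc1cc(NC(C)CCCNC(=O)n2nnc3ccccc32)c2ncccc2c1` carries a group of 9 heavy atoms (6 carbon, 3 nitrogen; one five-membered aromatic ring with 3 hetero atoms, one six-membered aromatic ring of carbon only) in place of a group of 8 heavy atoms (7 carbon, 1 nitrogen; one six-membered non-aromatic ring of carbon only), on a carbonyl carbon. The aromatic-for-saturated exchange in an at least 2.8-fold lower number from compound 1 to compound 2 (0.45 log units; beyond the scatter) lowered the number, so a lower number is expected for compound 4 as well, an at least 2.5-fold lower number from compound 1 to compound 4 (0.39 log units; beyond the scatter). Compound 4 is therefore estimated at 40000 nM, between 10000 nM and 100000 nM.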

Compound 4, half-maximal inhibitory concentration: > 100000 nM
Compound 4: no number, only a limit (the forecaster's own chance of this, stated with the estimate: 40%); middle value at least 2.5-fold (0.39 log units) away from the limit.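

On a carbonyl carbon, the fused aromatic group of compound 4 gives only a limit in this assay, > 100000 nM. An aromatic ring in the entering group is therefore not enough to give a readable number, and the exchange for the benzylamino group of compound 2 gives an at least 2.8-fold higher number from compound 2 to compound 4 (0.45 log units; beyond the scatter). The steps to compound 4 from compound 1 and from compound 3 cannot be read, because both ends of each are limits: the limit of > 100000 nM in this assay, at which 3 of the 4 values shown sit.

Still open, on these data alone, is whether an anilino or phenethylamino group on the carbonyl carbon would give a readable number like that of compound 2.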